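A Thiazole in Place of an Imidazole

A few compounds are considered here, and "the series" means these few. Any claim that something is new, unique, unknown or untested is made for them only; others in the source may bear on it.

Compound 1 `c1cncc(-c2ccccc2OCC2=NCCN2)c1` sets the reference: in a functional assay for activation of Alpha-1D adrenergic receptor (Homo sapiens), read by calcium flux (a lower number here means that less compound is needed, a higher number that more compound is needed for the effect), compound 1 gives 158 nM. Compound 2 `c1ccc(-c2ncc[nH]2)c(OCC2=NCCN2)c1` carries 1H-imidazol-2-yl in place of pyridin-3-yl on an aromatic carbon. In this assay compound 2 returns only a limit, < 100000 nM. The step from compound 1 to compound 2 is thus a step that the limit leaves unreadable from compound 1 to compound 2, its size hidden by the limit of < 100000 nM in this assay, at which 1 of the 2 values shown sits. Compound 3 `c1ccc(-c2nccs2)c(OCC2=NCCN2)c1` differs from compound 2 in one place: 1,3-thiazol-2-yl in place of 1H-imidazol-2-yl on an aromatic carbon. Among the measured compounds shown here, the only measured step that touches this position, from compound 1 to compound 2, cannot be read, and no other step bears on it. The entering thiazole shares with the pyridine of compound 1 the absence of a hydrogen-bond donor. The step expected from compound 2 to compound 3 is a step that the limit leaves unreadable from compound 2 to compound 3, toward less compound needed. Compound 3 is therefore estimated at 2000 nM, with a range from 300 nM to 30000 nM.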

Compound 3, half-maximal effective concentration: 31.6 nM
Compound 3: the middle estimate sits 63-fold (1.80 log units) above what was measured; measured number below the stated range.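

Among the compounds shown here, at this place on the aromatic ring, the change gives the first readable step in this assay: 1,3-thiazol-2-yl in place of pyridin-3-yl yields a 5.0-fold lower number from compound 1 to compound 3 (0.70 log units; beyond the scatter) on the shared core. For the compounds shown here, a five-membered aromatic ring with 0 hydrogen-bond donors is therefore compatible with activation at this place, which the earlier compounds could not show. The value of compound 2 is only a limit of the assay, and the steps that touch compound 2 cannot be read because of it: the limit of < 100000 nM in this assay, at which 1 of the 3 values shown sits.

What the compounds leave open is how a 1,3-oxazol-2-yl group or a plain phenyl ring would compare at this place. They also leave open whether the hydrogen-bond donor of 1H-imidazol-2-yl has any bearing on the result.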